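Swapping the aryl group on the piperazine-like core of compound 1

This account rests on a few compounds, and the source may have more. Where it says the series, first, only, none or still open, it means among the compounds named here.

Compound 1, `CC(C(=O)N1CCN(c2ccccc2F)CC1)N1C(=O)CCC1=O`, is the reference point of this small set. In a functional assay on the whole organism (strain Swiss) with Mus musculus as the target, in the maximal electroshock model, with a stated time of 0.25 h, at a dose of 100 mg/kg by the intraperitoneal route (a lower number here means a weaker effect, a higher number a stronger effect of the compound at the dose given), compound 1 gives 75%, which places it second highest of the three measured numbers. Compound 3, `CC(C(=O)N1CCN(c2ccccc2C(F)(F)F)CC1)N1C(=O)CCC1=O`, gives 100%, and the change of trifluoromethyl in place of fluoro on an aromatic carbon carries a number 25 percentage points higher from compound 1 to compound 3 (beyond the scatter). Compound 2, `CCC(C(=O)N1CCN(c2ccccc2F)CC1)N1C(=O)CCC1=O`, gives 0%; here methyl in place of hydrogen on a saturated chain carbon produces a number 75 percentage points lower from compound 1 to compound 2 (beyond the scatter).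

Compound 4, `CC(C(=O)N1CCN(c2cccc(Cl)c2)CC1)N1C(=O)CCC1=O`, has not yet been tested. It differs from compound 1 in one place: 3-chlorophenyl in place of 2-fluorophenyl on an amine nitrogen in a ring. Among the measured compounds shown here, no measured step changes the group on the amine nitrogen in a ring in exactly this way. The step from compound 1 to compound 3 is the only one that alters that same group, and it was a modest gain; the step from compound 1 to compound 2 concerns the saturated chain carbon and does not bear on this change. A step of the size seen from compound 1 to compound 3, in either direction, is therefore the most that can reasonably be expected, and the read-out cannot rise far above the value of compound 1.

Compound 4 is estimated at 75%, with a range from 25% to 100%, implying an expected step of no change at the digits printed from compound 1 to compound 4 (within the scatter).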

Compound 4, a percentage reported as activity, at one dose (the size of the read-out at that dose, not a potency): 50%
Beside the measured number, compound 4's estimate is 25 percentage points above it; the range from low to high includes it.
By their numbers in this assay, from the lowest: compound 2; then compound 4; then compound 1; then compound 3.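

In this assay, among the compounds shown here, the group on the amine nitrogen in a ring can now move the read-out in either direction: 3-chlorophenyl in place of 2-fluorophenyl gives a number 25 percentage points lower from compound 1 to compound 4 (beyond the scatter), while the only earlier change at this place, trifluoromethyl in place of fluoro, gave a number 25 percentage points higher from compound 1 to compound 3 (beyond the scatter). Unlike that earlier step, this one changes both the halogen and the numbered ring place it occupies in the phenyl group, so the drop cannot be assigned to either change alone, and 2-fluorophenyl is shown to be neither the best nor the poorest of the three aryl groups at this place in this small set. Nothing available explains why the read-out falls with this change.

The compounds shown leave open how 2-chlorophenyl or 3-fluorophenyl would read, as each would alter only one of the two features changed here. They also leave open what an unsubstituted phenyl group or a methoxy group on the phenyl ring would do, and whether the drop seen at this single dose would hold at other doses.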